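The compounds below may be only part of what the source reports. "The series", "measured", "known", "first", "only" and "open" are said of these compounds alone.

Measured compounds in a toxicity assay on cells (Macrophage, Mus musculus, strain BALB/c) for cytotoxicity, read by MTT assay; on this read-out higher numbers stand for weaker inhibition and lower numbers for stronger inhibition:
compound 1 `COc1cc(O)cc(O)c1C(=O)/C=C/c1ccccc1Br`, in this assay compound 1 gives 14600 nM
compound 2 `C=CCOc1cc(OC)c(C(=O)/C=C/Cc2ccccc2)c(OCC=C)c1`, in this assay compound 2 gives 14800 nM
compound 3 `COc1cc(/C=C/C(=O)c2c(O)cc(O)cc2OC)ccc1O`, in this assay compound 3 gives "not determined" (no result reported)

Compound 3 therefore stands nowhere on the numbers shown: its cytotoxicity was not determined, so it has no single value to compare with compound 1 or compound 2, whose values sit close together. Compound 4 `COc1cccc(/C=C/C(=O)c2c(O)cc(O)cc2OC)c1` differs from compound 3 in one place: hydrogen in place of hydroxy on an aromatic carbon. Within the data shown here, without a value for compound 3 there is no measured step to lean on, so the step from compound 3 to compound 4 in this assay is expected to be no more than a change within the scatter, in no clear direction. Compound 4 is expected to give about 15000 nM in this assay, within a range from 5000 nM to 45000 nM.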

Compound 4, half-maximal inhibitory concentration: 17600 nM
Estimate against measurement, compound 4: 1.2-fold (0.07 log units) below, and the stated range covers the measured number.
By their numbers in this assay, from the lowest: compounds 1, 2 and 4 (each within the scatter of the next).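

No step can be read between compound 3 and compound 4 in this assay. Going by these compounds, whether swapping hydroxy for hydrogen on the aromatic ring shifts this cytotoxicity remains open. Nothing shown offers an explanation for these values.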